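A few compounds are considered here, and "the series" means these few. Any claim that something is new, unique, unknown or untested is made for them only; others in the source may bear on it.

Working notes on the series.

Compound 2 `CCC/C=C/COCC1C2CCC(O2)C1C/C=C\CCCC(=O)O` is the stronger of the two measured compounds in a functional assay (plasma) for inhibition, with Homo sapiens as the target; a lower number here means a stronger inhibitor, a higher number a weaker inhibitor: compound 2 gives 300 nM, while compound 1 `O=C(O)CCC/C=C\CC1C2CCC(O2)C1COCCCc1ccccc1` gives 26000 nM. Going by the values given here, the one measured step, an 87-fold lower number from compound 1 to compound 2 (1.94 log units; beyond the scatter), concerns the exchange of a whole side group, not its geometry.

Compound 3 `CCC/C=C\COCC1C2CCC(O2)C1C/C=C\CCCC(=O)O` is the next candidate. Relative to compound 2 the change is the two compounds have the same atoms and bonds; at least one stereo element is drawn with a configuration in one of them and without one in the other: 1 of 6 stereo elements differ; a double bond is drawn E in compound 2 and Z in compound 3. Among the compounds with values here, no measured pair differs only in the geometry of a double bond, so the step from compound 1 to compound 2 bears on this change only indirectly, by showing that this side chain matters for the read-out. In the absence of a direct precedent, no step beyond the scatter is expected, a 1.3-fold higher number from compound 2 to compound 3 (0.12 log units; within the scatter), with wide uncertainty. For compound 3 the estimate in this assay is 400 nM, within a range of 80 nM to 2500 nM.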

Compound 3, half-maximal inhibitory concentration: 3300 nM
Beside the measured number, compound 3's estimate is 8.3-fold (0.92 log units) below it, and the stated range ends below it.
By their numbers in this assay, from the lowest: compound 2; then compound 3; then compound 1.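

In this assay, the double bond geometry alone gives an 11-fold higher number from compound 2 to compound 3 (1.04 log units; beyond the scatter), with no group entering or leaving, so this side chain matters for the read-out in its geometry as well as in its identity. Pent-1-en-1-yl in place of phenethyl still gives a 7.9-fold lower number from compound 1 to compound 3 (0.90 log units; beyond the scatter), so the gain over compound 1 is kept with the double bond drawn Z, though it is modest here. Reading the step from compound 2 to compound 3 as a clean E against Z comparison is subject to one qualification: the fact that one of compounds 2 and 3 is drawn with a defined configuration and the other without, at the place where they differ

The compounds shown leave open where a saturated pentyl chain or a longer alkenyl chain would fall at this place. They also leave open whether the preference for E over Z would hold on such a longer chain.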